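A few compounds are considered here, and "the series" means these few. Any claim that something is new, unique, unknown or untested is made for them only; others in the source may bear on it.

The measured compounds and their results in a functional assay on THP-1 cells (Homo sapiens); a higher number here means a larger maximal response, a lower number a smaller maximal response:

compound 1 `CCSC[C@@](O)([C@@H](Nc1cccc2nc(C)ccc12)c1ccc(C)cc1)C(F)(F)F` gives 87%

compound 2 `CCSC[C@@](O)([C@@H](Nc1cccc2nc(C)ccc12)c1cccc(F)c1OC)C(F)(F)F` gives 69%

compound 3 `CCSC[C@@](O)([C@@H](Nc1cccc2nc(C)ccc12)c1ccc(F)cc1OC)C(F)(F)F` gives 78%

Compound 3 stands second highest of these three numbers, but the two steps that reach it, a number 9 percentage points lower from compound 1 to compound 3 (within the scatter) and a number 9 percentage points higher from compound 2 to compound 3 (within the scatter), both lie within the scatter, so no order between compound 3 and either neighbour can be claimed. Compound 4 `CCSC[C@@](O)([C@@H](Nc1cccc2nc(C)ccc12)c1ccc(OC)c(F)c1)C(F)(F)F` has the same atoms as compound 3, joined differently: 3-fluoro-4-methoxyphenyl in place of 4-fluoro-2-methoxyphenyl on a saturated chain carbon bound to a nitrogen on an aromatic ring and a saturated chain carbon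

All three measured steps exchange the aromatic group on this same saturated chain carbon, so all of them bear on the change. Only one of them, a number 18 percentage points lower from compound 1 to compound 2 (beyond the scatter), reaches beyond the scatter, and it is modest. Among the measured compounds shown here, the one step that merely moves the fluorine on an otherwise unchanged group, a number 9 percentage points higher from compound 2 to compound 3 (within the scatter), stays within the scatter. Rearranging fluorine and methoxy on the ring is therefore expected to produce no step beyond the scatter in this assay, in either direction: the expected step is a number 1 percentage points higher from compound 3 to compound 4 (within the scatter). Compound 4 is estimated at 79% in this assay, with a range from 64% to 92%, wide enough to cover a shift of the size seen once among the measured compounds.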

Compound 4, largest response reached (Emax), in percent of the reference or control that the assay uses: 82%
For compound 4 the middle estimate is 3 percentage points below the measured one; the measured number falls inside the stated range.
By their numbers in this assay, from the lowest: compounds 2, 3, 4 and 1 (each within the scatter of the next, the first and the last beyond it).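

In this assay, placing 3-fluoro-4-methoxyphenyl on this saturated chain carbon gives a number 4 percentage points higher from compound 3 to compound 4 (within the scatter) and a number 13 percentage points higher from compound 2 to compound 4 (beyond the scatter), so this group cannot be told apart from 4-fluoro-2-methoxyphenyl but does stand apart from 3-fluoro-2-methoxyphenyl. Among the compounds shown here, this shows that rearranging the same fluorine and methoxy groups on the ring can produce a step beyond the scatter, which the one such step known earlier, between compound 2 and compound 3, did not show. The exchange of 4-methylphenyl for the new group gives a number 5 percentage points lower from compound 1 to compound 4 (within the scatter), so compound 1 and compound 4 cannot be ordered, and compound 2 is separated from both of them but not from compound 3.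

On these data alone, how an amine, a carboxylic acid or a longer chain would behave on this carbon in place of the aromatic group remains open, as does a phenyl ring carrying only a fluorine or only a methoxy group. No measurement shown bears on why these ring patterns differ.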